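A few compounds are considered here, and "the series" means these few. Any claim that something is new, unique, unknown or untested is made for them only; others in the source may bear on it.

Among the compounds with values here, in a functional assay on M21 cells (Homo sapiens) for antiproliferative activity, read by sulforhodamine B assay, with a stated time of 48 h (a higher number here means a weaker inhibitor, a lower number a stronger inhibitor), compound 3 (`CN1CCN(c2ccc(S(=O)(=O)Oc3cccc(I)c3)cc2)C1=O`) gives 400 nM, the lowest of the three numbers so far. Compound 1 (`Cc1ccc(OS(=O)(=O)c2ccc(N3CCN(C)C3=O)cc2)c(C)c1`) gives 1800 nM and compound 2 (`Cc1cccc(OS(=O)(=O)c2ccc(N3CCN(C)C3=O)cc2)c1`) gives 2300 nM.

The next step leads to compound 4 (`COc1ccc(OS(=O)(=O)c2ccc(N3CCN(C)C3=O)cc2)cc1`), with 4-methoxyphenyl in place of 3-iodophenyl on an oxygen.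

Within the data shown here, three measured steps bear on this change. Two are the steps toward the iodo compound, a 5.8-fold lower number from compound 2 to compound 3 (0.76 log units; beyond the scatter) and a 4.5-fold lower number from compound 1 to compound 3 (0.65 log units; beyond the scatter), both modest. The third, a 1.3-fold higher number from compound 1 to compound 2 (0.11 log units; within the scatter), shows that the 2,4-dimethylphenyl and 3-methylphenyl groups cannot be told apart in this assay. Among the measured compounds shown here, no methoxy compound has been measured, so the series gives only an indirect guide. Compound 4 carries no iodine, so a modest step to a higher number is expected in this assay, similar in size to a 5.8-fold lower number from compound 2 to compound 3 (0.76 log units; beyond the scatter), but with wide uncertainty.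

The estimated change is a 3.8-fold higher number from compound 3 to compound 4 (0.57 log units; beyond the scatter). Compound 4 is expected at 1500 nM, with an estimated range of 500 nM to 4500 nM.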

Compound 4, half-maximal inhibitory concentration: > 100000 nM
Compound 4: a limit, no number; the forecaster's own chance of this, stated with the estimate: 5%; middle value at least 66-fold (1.82 log units) from the limit.
By their numbers in this assay, from the lowest: compound 3; then compounds 1 and 2 (each within the scatter of the next). At a limit, above all of these: compound 4.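

In this assay compound 4 stands only at a limit, which is not a number: the limit of > 100000 nM in this assay, at which 1 of the 4 values shown sits.

On the oxygen whose other neighbour is the sulfonyl sulfur, the earlier changes gave only modest steps, whereas 4-methoxyphenyl gives the first large ones: an at least 250-fold higher number from compound 3 to compound 4 (2.39 log units; beyond the scatter), an at least 43-fold higher number from compound 2 to compound 4 (1.63 log units; beyond the scatter) and an at least 55-fold higher number from compound 1 to compound 4 (1.74 log units; beyond the scatter). Absence of iodine alone does not account for this, since compound 1 and compound 2 also carry none yet give measured values.

The compounds shown do not separate the methoxy group from its place on the ring, as 4-methoxyphenyl is the only group of its kind here. As far as these compounds go, how an amine or a carboxylic acid on that phenyl ring would read in this assay remains open.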